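Swapping the benzyl group on compound 3

The source may report more compounds than this note shows. Statements on the series, on what has been measured and on what is new or still open speak of the compounds shown alone.

In a functional assay on MGC-803 cells (Homo sapiens) for inhibition, read by CCK-8 assay, with a stated time of 48 h (a lower number here means a stronger inhibitor, a higher number a weaker inhibitor), compound 1 `COc1ccc(CN(C(=O)CSC(=S)N2CCCc3cc(C)ccc32)c2cc(OC)c(OC)c(OC)c2)cc1` gives 6490 nM. Compound 3 `COc1cc(N(Cc2ccc(Br)cc2)C(=O)CSC(=S)N2CCN(C(=O)OC(C)(C)C)CC2)cc(OC)c1OC` gives 12400 nM, within the scatter of compound 1. Compound 2 `COc1ccc(CN(C(=O)CSC(=S)N2CCN(C(=O)OC(C)(C)C)CC2)c2ccc(C)cc2)cc1` reads > 20000 nM, which is a limit of the assay.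

Compound 4 `COc1ccc(CN(C(=O)CSC(=S)N2CCN(C(=O)OC(C)(C)C)CC2)c2cc(OC)c(OC)c(OC)c2)cc1Br` carries 3-bromo-4-methoxyphenyl in place of 4-bromophenyl on a saturated chain carbon bound to an amide-type nitrogen. Among the compounds with values here, no measured pair isolates this change, so the only anchors in this assay are compound 3 at 12400 nM and compound 1 at 6490 nM. The expected step of a 1.6-fold lower number from compound 3 to compound 4 (0.19 log units; within the scatter) is small, toward a lower number, and stays within the scatter. For compound 4 the estimated value is 8000 nM, with an expected range of 2500 nM to 20000 nM.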

Compound 4, half-maximal inhibitory concentration: 3710 nM
For compound 4 the middle estimate is 2.2-fold (0.33 log units) above the measured one; the measured number falls inside the stated range.
By their numbers in this assay, from the lowest: compounds 4, 1 and 3 (each within the scatter of the next, the first and the last beyond it). At a limit, above all of these: compound 2.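

In this assay, within the data shown here, 3-bromo-4-methoxyphenyl in place of 4-bromophenyl on a saturated chain carbon bound to an amide-type nitrogen gives a 3.3-fold lower number from compound 3 to compound 4 (0.52 log units; beyond the scatter), the first single-place change that can be read, so the number does respond to the group at this place. The change adds methoxy and alters the bromine's place together, so the step cannot be assigned to either. Nothing shown gives a cause for the step.

Going by these compounds, how 3-bromophenyl alone or 4-methoxyphenyl alone would read at this place remains open. So does the effect of an amine or a carboxylic acid on this ring.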